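This account rests on a few compounds, and the source may have more. Where it says the series, first, only, none or still open, it means among the compounds named here.

Measured compounds:
- compound 1, `O=C(Nc1cccc(-n2cc(-c3ccncc3)c(-c3ccc(Cl)c(O)c3)n2)c1)Nc1cccc(C(F)(F)F)c1`: 6130 nM
- compound 2, `COc1cc(-c2nn(-c3cccc(NC(=O)Nc4cc(C(F)(F)F)cc(C(F)(F)F)c4)c3)cc2-c2ccncc2)ccc1Cl`: 1230 nM
- compound 3, `COc1cc(-c2nn(-c3cccc(NC(=O)Nc4cccc(C(F)(F)F)c4)c3)cc2-c2ccncc2)ccc1Cl`: 1870 nM

All three were tested in a functional assay on OVCAR-3 cells (Homo sapiens) for inhibition, read by sulforhodamine B assay, with a stated time of 48 h; a lower number here means a stronger inhibitor of growth, a higher number a weaker inhibitor of growth. Compound 3 stands second highest of these three numbers; its nearest neighbour is compound 2, separated by a 1.5-fold higher number from compound 2 to compound 3 (0.18 log units; within the scatter), and its furthest is compound 1, separated by a 3.3-fold lower number from compound 1 to compound 3 (0.52 log units; beyond the scatter). Of the two steps that are known, one concerns a change on the oxygen of the aromatic ring and the other the loss of one trifluoromethyl group.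

Compound 4, `COc1cc(-c2nn(-c3cccc(NC(=O)c4ccccc4)c3)cc2-c2ccncc2)ccc1Cl`, is the next compound, and it differs from compound 3 in one place: phenyl in place of (3-(trifluoromethyl)phenyl)amino on a carbonyl carbon. The change thus lies on the carbonyl carbon at the opposite end from the oxygen, so the step from compound 1 to compound 3 does not bear on it. The step from compound 2 to compound 3 removes a trifluoromethyl group and was within the scatter, but it keeps the amino nitrogen and a second aromatic ring, whereas here the amino nitrogen itself is lost. Among the compounds with values here, no measured pair shows this kind of exchange.

With no direct comparison, the estimate for compound 4 rests on caution: a step of a 1.9-fold higher number from compound 3 to compound 4 (0.27 log units; within the scatter) is expected, giving an expected value of 3500 nM for compound 4, with a range from 1000 nM to 12000 nM.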

Compound 4, concentration for total growth inhibition: 10900 nM
Compound 4: middle estimate off by 3.1-fold (0.49 log units), on the low side; the range from low to high includes it.
By their numbers in this assay, from the lowest: compounds 2 and 3 (each within the scatter of the next); then compounds 1 and 4 (each within the scatter of the next).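

In this assay, exchanging the (3-(trifluoromethyl)phenyl)amino group on the carbonyl carbon for phenyl gives a 5.8-fold higher number from compound 3 to compound 4 (0.77 log units; beyond the scatter), so this end of the molecule can move the number beyond the scatter. Within the data shown here, the earlier step at this end, the removal of one trifluoromethyl group, stayed within the scatter; this one is the first to show that a change here can weaken growth inhibition measurably, and it is a larger step than the change on the oxygen of the aromatic ring. The exchange removes a nitrogen, along with one hydrogen-bond donor, as well as a trifluoromethyl group, and no evidence here explains why the number rises.

The compounds shown do not separate the loss of the amino nitrogen from the loss of the trifluoromethyl group, and a plain phenylamino group on the same carbonyl carbon would pull those two apart. From the compounds shown here alone, it also remains open how a benzyl group, with a carbon chain in place of the amino nitrogen, or a cyclohexyl ring in place of the phenyl ring, would fare at this position.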